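A few compounds are considered here, and "the series" means these few. Any claim that something is new, unique, unknown or untested is made for them only; others in the source may bear on it.

Of the compounds shown here, three built on one shared core have been measured. Compound 1 `O=C1C(Nc2ccc(Br)cc2)=CC(=O)c2c1nc1n2[C@H]2OC[C@@H](O)[C@H]2OC1` gives 2020 nM in a functional assay on MGC-803 cells (Homo sapiens) for inhibition, read by sulforhodamine B assay; on this read-out lower numbers stand for stronger inhibition and higher numbers for weaker inhibition. Compound 2 `O=C1C=C(Nc2ccccc2F)C(=O)c2c1nc1n2[C@H]2OC[C@@H](O)[C@H]2OC1` gives 2080 nM in this assay, and compound 3 `COc1ccc(NC2=CC(=O)c3c(nc4n3[C@H]3OC[C@@H](O)[C@H]3OC4)C2=O)cc1` gives 2150 nM in this assay. On these numbers compound 2 cannot be told apart from compound 1 or from compound 3, since each gap lies within the usual scatter of repeated measurements. Among the compounds with values here, the single measured step, a 1.1-fold higher number from compound 1 to compound 3 (0.03 log units; within the scatter), is likewise within the scatter, so exchanging methoxy for bromo on the aromatic carbon left the read-out unchanged.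

Compound 4 `O=C1C=C(Nc2ccc(I)cc2)C(=O)c2c1nc1n2[C@H]2OC[C@@H](O)[C@H]2OC1` has not yet been measured. It differs from compound 2 by 4-iodophenyl in place of 2-fluorophenyl on an amine nitrogen. Within the data shown here, no measured step covers this exact exchange; the closest guide is compound 1, which carries bromo on its ring and gives 2020 nM, matching compound 2 within the scatter. Compound 4 is therefore expected to stay within the scatter of compound 2, with a step of a 1.0-fold higher number from compound 2 to compound 4 (0.00 log units; within the scatter) predicted. The estimated value for compound 4 is 2100 nM, with a range from 1000 nM to 4500 nM.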

Compound 4, half-maximal inhibitory concentration: 1400 nM
For compound 4 the middle estimate is 1.5-fold (0.18 log units) above the measured one; the measured number falls inside the stated range.
By their numbers in this assay, from the lowest: compounds 4, 1, 2 and 3 (each within the scatter of the next).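

In this assay the exchange of 2-fluorophenyl for 4-iodophenyl on an amine nitrogen gives a 1.5-fold lower number from compound 2 to compound 4 (0.17 log units; within the scatter) and so cannot be told apart from no change at all. Within the data shown here, the earlier step altered only one group on the aromatic ring, whereas this one replaces the halogen and, going by the two group names, also moves it to a different ring position. Even so, the read-out stays within the usual scatter, so this position tolerates both kinds of difference in these two compounds.

Still open, on these data alone, is whether a group of another kind on this amine nitrogen, such as a short alkyl chain or a phenyl ring carrying a carboxylic acid or an amine, would shift the number beyond the scatter. No supporting data are available to explain the result.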